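Amide Substituent Variation in Phosphofructokinase-Bisphosphatase Inhibitors

The source may hold more compounds than are shown below. What is called first, only, known or untested is meant among the compounds shown, and "the series" means these compounds.

Of the compounds shown here, two have been measured in an assay for inhibition of 6-phosphofructo-2-kinase/fructose-2,6-bisphosphatase 3 (Homo sapiens), read by ADP-Glo, with a stated time of 2 h; on this read-out lower numbers stand for stronger inhibition and higher numbers for weaker inhibition. Compound 1 `CN(C)S(=O)(=O)c1ccccc1Nc1cc(-c2ccc3ccn(C)c3c2)c2nccnc2c1` gives 94 nM in this assay. Compound 2 `CN1CCC(NC(=O)c2ccncc2Nc2cc(-c3ccc4ccn(C)c4c3)c3nccnc3c2)CC1` gives 38 nM in this assay, the lower of the two numbers, and its gap to compound 1 lies beyond the usual scatter. For the measured compounds named here, no pair of measured compounds differs in only one place, so no single step has been read directly.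

Compound 3 `CN1CCC(N(C)C(=O)c2ccncc2Nc2cc(-c3ccc4ccn(C)c4c3)c3nccnc3c2)C1` has not yet been measured. It differs from compound 2 by one change: methyl(1-methylpyrrolidin-3-yl)amino in place of (1-methylpiperidin-4-yl)amino on a carbonyl carbon. The group that leaves carries one hydrogen-bond donor and the group that enters carries none, and a six-membered non-aromatic ring gives way to a five-membered one, with the same atoms joined differently. Without a measured step of this kind to lean on, the expected step of a 1.7-fold higher number from compound 2 to compound 3 (0.23 log units; within the scatter) is a modest weakening that could still fall within the scatter. Compound 3 is expected to give 65 nM in this assay, within a range from 20 nM to 220 nM.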

Compound 3, half-maximal inhibitory concentration: 176 nM
Compound 3: the middle estimate sits 2.7-fold (0.43 log units) below what was measured, and the stated range covers the measured number.
By their numbers in this assay, from the lowest: compound 2; then compounds 1 and 3 (each within the scatter of the next).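

Read in this assay, the change from (1-methylpiperidin-4-yl)amino to methyl(1-methylpyrrolidin-3-yl)amino on the carbonyl carbon gives a 4.6-fold higher number from compound 2 to compound 3 (0.67 log units; beyond the scatter), the first step in this set that can be read directly. The two groups hold the same atoms, so the number at this position depends on how those atoms are joined and not only on which atoms are present. The step combines two differences, the loss of the hydrogen-bond donor and a six-membered non-aromatic ring giving way to a five-membered one, and nothing available here explains the result.

Which of those two differences carries the step remains open. Also open, as far as these compounds go, is how methyl(1-methylpiperidin-4-yl)amino, which would keep the six-membered ring without the donor, or a morpholine on the same carbonyl carbon would read.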